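A Silicon-Bearing Group in Place of Tert-Butyl

The source may report more compounds than this note shows. Statements on the series, on what has been measured and on what is new or still open speak of the compounds shown alone.

Of the compounds shown here, two have been measured so far in an ADME assay on a cell-free system (plasma) for metabolic stability, in the presence of a further agent that is not named here; on this read-out lower numbers stand for a shorter-lived compound and higher numbers for a longer-lived compound. Compound 1 (`CC(C)Cc1ccc(C(C)C(=O)OCc2ccc(OC(=O)OCCC(C)(C)C)cc2)cc1`) gives 3.4 h. Compound 2 (`COc1ccc2cc([C@H](C)C(=O)OCc3ccc(OC(=O)OCCC(C)(C)C)cc3)ccc2c1`) gives 2.25 h, and this number lies within the usual scatter of the number for compound 1, so the data do not separate the two.

Compound 3 (`COc1ccc2cc([C@H](C)C(=O)OCc3ccc(OC(=O)OCC[Si](C)(C)C)cc3)ccc2c1`) has not yet been measured. It differs from compound 2 in one place, on a saturated chain carbon, two bonds along the chain from an oxygen next to a carbonyl group: a group of 4 heavy atoms (3 carbon, 1 silicon; no ring) in place of a group of 4 heavy atoms (4 carbon; no ring), on a saturated chain carbon, two bonds along the chain from an oxygen next to a carbonyl group. A tert-butyl leaves, and a group of the same heavy-atom count, with one silicon among its atoms, enters.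

Among the compounds with values here, no measured pair differing in one place is available, so the data offer no direct guide to this change in this assay. The expectation is therefore no step beyond the scatter, in either direction, with compound 2 at 2.25 h as the starting point. The estimated size of a 1.0-fold higher number from compound 2 to compound 3 (0.01 log units; within the scatter) is small. For compound 3 the expected half-life is 2.3 h, with an estimated range of 1.3 h to 4 h.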

Compound 3, half-life: 4.22 h
Estimate against measurement, compound 3: 1.8-fold (0.26 log units) below; measured number outside the range, above it.
By their numbers in this assay, from the lowest: compounds 2, 1 and 3 (each within the scatter of the next).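

In this assay, within the data shown here, putting the silicon-bearing group in place of tert-butyl, on a saturated chain carbon, two bonds along the chain from an oxygen next to a carbonyl group, gives a 1.9-fold higher number from compound 2 to compound 3 (0.27 log units; within the scatter) and so supplies the first reading of a change in one place. The earlier compounds shown here could not show this, since compound 1 and compound 2 differ elsewhere: on the core of compound 2, this position takes a silicon atom within the group without a step beyond the scatter, and the data do not separate compound 3 from compound 2. Nothing measured here bears on why the two half-lives stand where they do.

The compounds shown leave open whether the same exchange on the core of compound 1 would give a step of like size, since that pair is not among them. They also leave open how a longer chain, a cyclohexyl group or an amine at this place would read in this assay, and whether any such group would move the half-life beyond the scatter.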